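Mirror-image ketal ester and fatty-acid amide hydrolase inhibition

The source may hold more compounds than are shown below. What is called first, only, known or untested is meant among the compounds shown, and "the series" means these compounds.

Measured compounds:
compound 1, `CCCCC/C=C\C/C=C\C/C=C\C/C=C\CCCC(=O)OCC1COC(C)(C)O1`, 98000 nM
compound 2, `CCCCC/C=C\C/C=C\C/C=C\C/C=C\CCCC(=O)OC[C@H]1COC(C)(C)O1`, 28000 nM

Going by the values given here, in an assay on membranes from cerebellum for inhibition of Fatty-acid amide hydrolase 1 (Rattus norvegicus) (a higher number here means a weaker inhibitor, a lower number a stronger inhibitor), compound 2 gives the lower of the two numbers so far, and compound 1 sits at a 3.5-fold lower number from compound 1 to compound 2 (0.54 log units; beyond the scatter) away from it. Among the compounds with values here, the only measured step, therefore, is a modest one. Compound 3, `CCCCC/C=C\C/C=C\C/C=C\C/C=C\CCCC(=O)OC[C@@H]1COC(C)(C)O1`, is the next point: it is the mirror image of compound 2 at the ring, as the two compounds have the same atoms and bonds and differ only in configuration as drawn: 1 of 5 stereo elements differ; a stereocentre at a saturated ring carbon is drawn R in compound 2 and S in compound 3 states. The step from compound 1 to compound 2 bears on this because the fact that one of compounds 1 and 2 is drawn with a defined configuration and the other without, at the place where they differ: compound 1, drawn without a configuration, stands between the two single forms, and its number is well to the weaker side of compound 2. The other single form, compound 3, is therefore expected to land on the weaker side again, with an estimated step of a 7.1-fold higher number from compound 2 to compound 3 (0.85 log units; beyond the scatter) in this assay. For compound 3 the estimate is 200000 nM, with a range from 70000 nM to 600000 nM.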

Compound 3, half-maximal inhibitory concentration: 17000 nM
Estimate against measurement, compound 3: 12-fold (1.07 log units) above, outside the stated range (below it).
By their numbers in this assay, from the lowest: compounds 3 and 2 (each within the scatter of the next); then compound 1.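

In this assay, changing this saturated ring carbon from R to S gives a 1.6-fold lower number from compound 2 to compound 3 (0.22 log units; within the scatter), so the two mirror-image forms cannot be ranked. Compound 1, drawn without a configuration, does not fall within the span of these two single forms, and its distance from one of them is a 5.8-fold lower number from compound 1 to compound 3 (0.76 log units; beyond the scatter). The earlier step from compound 1 therefore did not signal a real preference for one configuration at this carbon, since the two defined forms give matching numbers: the fact that compounds 2 and 3 differ only in the configuration as drawn

Why compound 1 gives the higher number remains open. Also open, from the compounds shown here alone, is whether the mirror-image forms would still match with an amide in place of the ester, or with a diol bearing two hydroxyl groups in place of the ketal.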